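Bile acid receptor agonists: para-substituent change on the benzamide

This account rests on a few compounds, and the source may have more. Where it says the series, first, only, none or still open, it means among the compounds named here.

Measured so far:
compound 1 `CC(C)S(=O)(=O)Nc1ccc(CNC(=O)c2ccc(C(C)(C)C)cc2)c(Cl)c1`: 420 nM
compound 2 `CC(C)(C)c1ccc(C(=O)NCc2ccc(NS(=O)(=O)C3CC3)cc2Cl)cc1`: 1500 nM
compound 3 `CS(=O)(=O)Nc1ccc(CNC(=O)c2ccc(C3(C(F)(F)F)CC3)cc2)c(Cl)c1`: 540 nM

Compound 3 gives 540 nM in an assay on HeLa cells for agonist activity at Bile acid receptor (Homo sapiens), read by a luciferase reporter, with a stated time of 24 h; on this read-out higher numbers stand for an effect only at larger amounts of compound and lower numbers for an effect already at smaller amounts; this lies within the usual scatter of compound 1 at 420 nM, and compound 2 gives 1500 nM. Compound 4 `CN(C)c1ccc(C(=O)NCc2ccc(NS(C)(=O)=O)cc2Cl)cc1` carries the change (dimethylamino in place of 1-(trifluoromethyl)cyclopropyl on an aromatic carbon). Within the data shown here, the only measured step, a 3.6-fold higher number from compound 1 to compound 2 (0.55 log units; beyond the scatter), concerns the sulfonyl substituent, not the benzamide para position, so no measured step bears directly on this change; the data give no step for the group entering here. With nothing comparable measured, the expectation is uncertain and rests on the observation that all three measured compounds carry a branched carbon group at this position. The estimate for compound 4 is 2000 nM with a range of 500 nM to 8000 nM. The step expected here is a 3.7-fold higher number from compound 3 to compound 4 (0.57 log units; beyond the scatter), and nothing comparable has yet been tested.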

Compound 4, half-maximal effective concentration: 1460 nM
Compound 4: the middle estimate sits 1.4-fold (0.14 log units) above what was measured, within the range that was stated.
By their numbers in this assay, from the lowest: compounds 1 and 3 (each within the scatter of the next); then compounds 4 and 2 (each within the scatter of the next).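

In this assay, dimethylamino in place of 1-(trifluoromethyl)cyclopropyl gives a 2.7-fold higher number from compound 3 to compound 4 (0.43 log units; beyond the scatter), the first step read at this position on the aromatic ring. The benzamide substituent therefore shifts the number beyond the scatter, and the change also shows that a nitrogen-bearing group without a ring still gives a measurable effect. No evidence at hand accounts for this step. Going by these compounds, the change swaps ring, fluorines and nitrogen together, so their separate contributions remain open. On these data alone, how a methoxy group or a carboxylic acid at this position would compare also remains open.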